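Chloro in place of nitro on an aromatic carbon

A few compounds are considered here, and "the series" means these few. Any claim that something is new, unique, unknown or untested is made for them only; others in the source may bear on it.

Only two results are available for this small series built on a shared core. In a functional assay on THP-1 cells (Homo sapiens) for cytotoxicity, read by MTT assay, with a stated time of 24 h (on this read-out lower numbers stand for stronger inhibition and higher numbers for weaker inhibition), compound 1 (`C=C1CC[C@H]2C(C)(C)CCC[C@]2(C)[C@H]1CCC(C)CC(=O)OC`) gives > 200000 nM as its result, and this is a limit of the assay rather than a number. For the measured compounds named here, compound 2 (`CC(CC[C@H]1/C(=C/c2ccc([N+](=O)[O-])cc2)CC[C@H]2C(C)(C)CCC[C@]12C)CC(=O)O`) gives 180000 nM in this assay and so holds the only actual number.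

Compound 3 (`CC(CC[C@H]1/C(=C/c2ccc(Cl)cc2)CC[C@H]2C(C)(C)CCC[C@]12C)CC(=O)O`) has not yet been measured. It differs from compound 2 in one place, on an aromatic carbon of a six-membered aromatic ring of carbon only, para to a large group, where chloro stands in place of nitro (chloro in place of nitro on an aromatic carbon). Put another way, 4-nitrophenyl becomes 4-chlorophenyl. Going by the values given here, no measured pair shows what this exchange does, so the expectation is loose. In this assay no change beyond the usual scatter is expected in either direction, and the expected step of a 1.2-fold lower number from compound 2 to compound 3 (0.08 log units; within the scatter) is correspondingly small. Compound 3 is estimated at 150000 nM with an expected range from 60000 nM to 250000 nM in all.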

Compound 3, half-maximal inhibitory concentration: > 200000 nM
Compound 3 ended at the assay's limit; the forecaster's own chance of this, stated with the estimate: 30%; middle value at least 1.3-fold (0.12 log units) away from the limit.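

The exchange of nitro for chloro on this aromatic carbon, para to a large group, gives an at least 1.1-fold higher number from compound 2 to compound 3 (0.04 log units; that floor lies within the scatter) in this assay. For the compounds shown here, this is the first reading of the change on the shared core, but it gives only a floor, so the true size of the step could lie within the scatter or beyond it. Going from 4-nitrophenyl to 4-chlorophenyl gave no lower number, and the assay leaves little room to read any change at this position: the limit of > 200000 nM in this assay, at which 2 of the 3 values shown sit.

What the compounds shown leave open is whether another group on this aromatic carbon, such as an amine or a methoxy group, would give a number clearly lower than that of compound 2. They also leave open whether a longer chain carrying the carboxylic acid would change how the 4-chlorophenyl and 4-nitrophenyl compounds compare.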